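This account rests on a few compounds, and the source may have more. Where it says the series, first, only, none or still open, it means among the compounds named here.

Measured so far in a functional assay on DU-145 cells (Homo sapiens) for cytotoxicity, read by MTT assay; a lower number here means a stronger inhibitor, a higher number a weaker inhibitor:
compound 1 `CC(O)(CS(=O)(=O)c1ccc(Cl)cc1)c1nc(-c2ccc(Cl)cc2)no1` gives > 100000 nM, which is a limit of this assay and not a number.
compound 2 `CC(O)(CS(=O)(=O)c1ccc(Cl)cc1)c1nc(-c2ccc(F)c(Cl)c2)no1` gives 35500 nM.

Compound 1 therefore stands at the limit, with the limit of > 100000 nM in this assay, at which 1 of the 2 values shown sits; no number is known for it. For the measured compounds named here, the only measured step, an at least 2.8-fold lower number from compound 1 to compound 2 (0.44 log units; beyond the scatter), alters the ring attached to the oxadiazole side of the shared core, not the ring carrying the sulfonyl group.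

Compound 3 `CC(O)(CS(=O)(=O)c1ccc(Br)cc1)c1nc(-c2ccc(Cl)cc2)no1` differs from compound 1 by bromo in place of chloro on an aromatic carbon. Going by the values given here, no measured step touches this position, so nothing speaks directly to the change. With compound 1 at the limit and a change of one halogen for another, no step beyond the scatter is expected; compound 3 is expected to remain near the limit of this assay. The step expected from this change is a step that the limit leaves unreadable from compound 1 to compound 3. For compound 3 the estimate is 150000 nM, with a range from 40000 nM to 600000 nM.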

Compound 3, half-maximal inhibitory concentration: > 100000 nM
Compound 3 ended at the assay's limit (the forecaster's own chance of this, stated with the estimate: 70%); the middle value is on the limit's open side.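

In this assay compound 3 gives > 100000 nM, a limit and not a number. Compound 1 stands at the same limit, so no step can be read between compound 1 and compound 3: the limit of > 100000 nM in this assay, at which 2 of the 3 values shown sit.

On these data alone, whether bromo in place of chloro on an aromatic carbon shifts the number at all remains open.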